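Hydrazone aryl replacement in the cytotoxicity series

The compounds below may be only part of what the source reports. "The series", "measured", "known", "first", "only" and "open" are said of these compounds alone.

Values in a functional assay on A549 cells (Homo sapiens) for cytotoxicity, read by MTT assay, with a stated time of 72 h (a higher number here means a weaker inhibitor, a lower number a stronger inhibitor), so far:
compound 1 `CN(C)CCn1cnnc1-c1cc(Oc2ccc(NC(=O)N/N=C/c3ccc(F)cc3Cl)cc2F)ccn1`: 1120 nM
compound 2 `CN(C)CCn1cnnc1-c1cc(Oc2ccc(NC(=O)N/N=C/c3ccc(O)c(F)c3)cc2F)ccn1`: 13400 nM
compound 3 `CN(C)CCn1cnnc1-c1cc(Oc2ccc(NC(=O)N/N=C/c3ccc(O)c(O)c3)cc2F)ccn1`: > 100000 nM

The value for compound 3 is a limit of the assay, not a number (the limit of > 100000 nM in this assay, at which 1 of the 3 values shown sits). Compound 1 holds the lowest of the two numbers given; the nearest is compound 2, a 12-fold higher number from compound 1 to compound 2 (1.08 log units; beyond the scatter).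

Compound 4 `CN(C)CCn1cnnc1-c1cc(Oc2ccc(NC(=O)N/N=C/c3c(O)ccc4ccccc34)cc2F)ccn1` is not yet measured in this assay. Relative to compound 1 it carries 2-hydroxynaphthalen-1-yl in place of 2-chloro-4-fluorophenyl on a carbon with a double bond to nitrogen. Both measured steps from compound 1 bring in a hydroxy group and are large: a 12-fold higher number from compound 1 to compound 2 (1.08 log units; beyond the scatter) and an at least 89-fold higher number from compound 1 to compound 3 (1.95 log units; beyond the scatter), with an at least 7.4-fold higher number from compound 2 to compound 3 (0.87 log units; beyond the scatter) between them. For the measured compounds named here, since a hydroxy group enters here too, a weaker compound is expected, a 7.1-fold higher number from compound 1 to compound 4 (0.85 log units; beyond the scatter), though the added ring has no measured precedent. Compound 4 is estimated at 8000 nM, between 2000 nM and 40000 nM.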

Compound 4, half-maximal inhibitory concentration: 880 nM
The estimate for compound 4 lay 9.1-fold (0.96 log units) above the measured number, outside the stated range (below it).
By their numbers in this assay, from the lowest: compounds 4 and 1 (each within the scatter of the next); then compound 2. At a limit, above all of these: compound 3.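

In this assay, a hydroxy group at this position does not by itself bring a loss: a 1.3-fold lower number from compound 1 to compound 4 (0.10 log units; within the scatter), while a 15-fold lower number from compound 2 to compound 4 (1.18 log units; beyond the scatter). The 2-hydroxynaphthalen-1-yl of compound 4 thus sits level with the 2-chloro-4-fluorophenyl of compound 1, unlike the hydroxy-bearing groups of compound 2 and compound 3. Compound 3 stands at a limit of the assay, not a number, so an at least 110-fold lower number from compound 3 to compound 4 (2.05 log units; beyond the scatter) is a bound only: the limit of > 100000 nM in this assay, at which 1 of the 4 values shown sits.

The compounds shown do not separate the added ring from the hydroxy group. From the compounds shown here alone, what a methoxy group in place of that hydroxy would give remains open.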